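The source may report more compounds than this note shows. Statements on the series, on what has been measured and on what is new or still open speak of the compounds shown alone.

Working notes on the series. Among the compounds with values here, compound 1 `Cc1ccc(-c2nccs2)c(C(=O)N2CC3(CC3)C[C@H]2CNc2ccc(C(F)(F)F)cn2)n1` gives 8.6 in a functional assay on CHO cells for antagonist activity at Orexin/Hypocretin receptor type 1 (Homo sapiens), read by FLIPR and calcium flux (a lower number here means a less potent compound, a higher number a more potent compound, by a factor of ten per unit of this negative logarithm), and stands highest of the two numbers so far; the nearest is compound 2 `Cc1nc(C(=O)N2CC3(CC3)C[C@H]2CNc2cc(C(F)(F)F)ccn2)c(-c2ccccc2)s1`, which gives 8.2 in this assay, a gap beyond the usual scatter. Compound 3 `Cc1ccc(-c2ccccc2)c(C(=O)N2CC3(CC3)C[C@H]2CNc2ccc(C(F)(F)F)cn2)n1` is not yet measured. It differs from compound 1 as follows: phenyl in place of 1,3-thiazol-2-yl on an aromatic carbon. Within the data shown here, no measured pair isolates this change, so the step is expected to be small, at most around the scatter and if anything downward, a number 0.30 log units lower from compound 1 to compound 3 (within the scatter). Compound 3 is therefore estimated at 8.3 in this assay, within 7.7 to 8.9.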

Compound 3, negative logarithm of the antagonist equilibrium constant: 8.6
Compound 3: the middle estimate sits 0.30 log units below what was measured, and the stated range covers the measured number.
By their numbers in this assay, from the lowest: compound 2; then compounds 1 and 3 (each within the scatter of the next).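

In this assay, phenyl in place of 1,3-thiazol-2-yl on the aromatic carbon gives no change at the digits printed from compound 1 to compound 3 (within the scatter), so in this pair a six-membered aromatic ring of carbon only reads the same as a five-membered aromatic ring with 2 hetero atoms. The hydrogen-bond acceptors counted on 1,3-thiazol-2-yl are therefore not needed at this position to hold the number. No evidence bears on why the two rings read alike. Still open, going by these compounds, is whether a non-aromatic group here, such as an amine or a carboxylic acid, would hold the number.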